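Methoxy to hydroxy on the shared core: cytotoxicity notes

A few compounds are considered here, and "the series" means these few. Any claim that something is new, unique, unknown or untested is made for them only; others in the source may bear on it.

Measured in an ADME assay on HepG2 2.2.15 cells (Homo sapiens) for cytotoxicity, read by MTT assay, with stated times of 48 h and 9 days; on this read-out lower numbers stand for higher toxicity in this test and higher numbers for lower toxicity in this test:

compound 1, `O=C(/C=C/c1coc2cc(O)ccc2c1=O)NCc1ccccc1`, 436000 nM
compound 2, `COc1ccc2c(=O)c(/C=C/C(=O)NCc3ccccc3)coc2c1`, 376000 nM
compound 3, `COc1ccc(NC(=O)/C=C/c2coc3cc(OC)ccc3c2=O)cc1`, 718000 nM

Compound 2 serves as the reference point for both measured steps. The change hydrogen in place of methyl on an oxygen on an aromatic ring gives a 1.2-fold higher number from compound 2 to compound 1 (0.06 log units; within the scatter). The change (4-methoxyphenyl in place of benzyl on an amide-type nitrogen), which is where the cores of compound 2 and compound 3 part, gives a 1.9-fold higher number from compound 2 to compound 3 (0.28 log units; within the scatter). The numbers of compound 1 and compound 3 are also within the scatter of each other, so the three measured compounds cannot be told apart in this assay on the basis of these results.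

Compound 4, `COc1ccc(NC(=O)/C=C/c2coc3cc(O)ccc3c2=O)cc1`, is not yet measured. It differs from compound 3 by hydrogen in place of methyl on an oxygen on an aromatic ring. The place where this change sits is described in the same words as for the change from compound 2 to compound 1, so it is the same change applied to the other core. Among the measured compounds shown here, for compound 4 a step of a 1.1-fold higher number from compound 3 to compound 4 (0.05 log units; within the scatter) is expected in this assay, resting on the earlier result a 1.2-fold higher number from compound 2 to compound 1 (0.06 log units; within the scatter), which the present data give as the only example of this change. On that footing compound 4 is estimated at 800000 nM in this assay, with an expected range from 400000 nM to 1600000 nM.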

Compound 4, half-maximal cytotoxic concentration: 976000 nM
Compound 4: the middle estimate sits 1.2-fold (0.09 log units) below what was measured; the measured number falls inside the stated range.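

In this assay, methoxy to hydroxy on the core of compound 3 gives a 1.4-fold higher number from compound 3 to compound 4 (0.13 log units; within the scatter), which agrees with the same change on the core of compound 2: the same change on two cores in this assay, a 1.2-fold higher number (0.06 log units; within the scatter) from compound 2 to compound 1 and a 1.4-fold higher number (0.13 log units; within the scatter) from compound 3 to compound 4, 1.2-fold (0.07 log units) apart, within the scatter of two such steps. On the hydroxy core, 4-methoxyphenyl in place of benzyl on the amide-type nitrogen gives a 2.2-fold higher number from compound 1 to compound 4 (0.35 log units; beyond the scatter), and this also agrees with the same change on the methoxy core: the same change on two cores in this assay, a 1.9-fold higher number (0.28 log units; within the scatter) from compound 2 to compound 3 and a 2.2-fold higher number (0.35 log units; beyond the scatter) from compound 1 to compound 4, 1.2-fold (0.07 log units) apart, within the scatter of two such steps. Both changes therefore carry from one core to the other without a detectable difference in step size, but each rests on only two examples, the methoxy-to-hydroxy steps do not show a real shift on either core, and only the step to compound 4 from compound 1 lies beyond the scatter, so a firm effect of the amide change on both cores is not shown.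

As far as these compounds go, whether this agreement holds for other groups on the oxygen, such as an ethyl group or a longer alkyl chain, or for an amine in place of the hydroxy, remains open. The compounds shown also leave open how an alkyl chain on the amide-type nitrogen, or a phenyl ring carrying a carboxylic acid there, would behave.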